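Swapping one aromatic group: expectations for compound 3

The source may hold more compounds than are shown below. What is called first, only, known or untested is meant among the compounds shown, and "the series" means these compounds.

- Compound 1 `COc1ccc(/C=C2\CCC/C(=C\c3ccc(Br)cc3)C2=O)cc1OC` gives 13100 nM
- Compound 2 `COc1ccc(/C=C2\CCC/C(=C\c3cc(Cl)cc(Cl)c3)C2=O)cc1OC` gives 8300 nM

Both numbers come from an ADME assay on NHDF cells (Homo sapiens) for cytotoxicity, read by MTT assay, with a stated time of 72 h; on this read-out higher numbers stand for weaker inhibition and lower numbers for stronger inhibition. Going by the values given here, only one step has been measured so far, a 1.6-fold lower number from compound 1 to compound 2 (0.20 log units; within the scatter). Among the compounds with values here, on these numbers the two compounds cannot be told apart, so compound 2 stands level with its only neighbour.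

The next compound is compound 3 `COc1cc(/C=C2\CCC/C(=C\c3ccc(OC)c(OC)c3)C2=O)ccc1O`. It differs from compound 2 in one place: 4-hydroxy-3-methoxyphenyl in place of 3,5-dichlorophenyl on a double-bonded chain carbon bound to a double-bonded ring carbon. This is the same place that changed in the measured step, which stayed within the scatter. That step is a thin guide, however, as it only exchanged one halogen-bearing phenyl group for another. Within the data shown here, no measured compound carries the 4-hydroxy-3-methoxyphenyl group, so the range must stay wide. No step beyond the scatter is therefore expected in this assay, in either direction. The estimated change is a 1.1-fold higher number from compound 2 to compound 3 (0.04 log units; within the scatter). For compound 3 the expected value is about 9000 nM, with an estimated range from 3500 nM to 23000 nM.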

Compound 3, half-maximal inhibitory concentration: 13700 nM
Compound 3: the middle estimate sits 1.5-fold (0.18 log units) below what was measured; the range from low to high includes it.
By their numbers in this assay, from the lowest: compounds 2, 1 and 3 (each within the scatter of the next).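

In this assay the steps at this position are a 1.7-fold higher number from compound 2 to compound 3 (0.22 log units; within the scatter) and a 1.0-fold higher number from compound 1 to compound 3 (0.02 log units; within the scatter) even though a halogen-bearing phenyl group has given way to 4-hydroxy-3-methoxyphenyl, a group with no halogen that brings a hydrogen-bond donor and hydrogen-bond acceptors. Going by these compounds alone, the earlier pair only exchanged one halogen-bearing phenyl group for another, so this is the first sign that a change in the kind of atoms on this ring, and not just a change of halogen, can leave the number within the scatter; on these values compound 1, compound 2 and compound 3 cannot be told apart. Nothing in the available data offers an explanation for how closely these values sit together.

Within the data shown here, every group at this position so far is still a six-membered aromatic ring of carbon only, so it remains open whether an amine, a carboxylic acid or a longer chain in place of that ring would give a step beyond the scatter. From the compounds shown here alone, it is also open whether the same exchanges would read alike in a different cell type.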